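The source may hold more compounds than are shown below. What is called first, only, known or untested is meant among the compounds shown, and "the series" means these compounds.

Measured compounds:
- compound 1 `CCCCCc1ccc(-c2cn(C[C@H](O)[C@H]3OC(=O)C(OCc4ccccc4)=C3OCc3ccccc3)nn2)cc1`: in a functional assay on HCT-116 cells (Homo sapiens) for antiproliferative activity, read by MTT assay, with a stated time of 72 h (a higher number here means a weaker inhibitor, a lower number a stronger inhibitor), compound 1 gives 13800 nM.
- compound 2 `CC(C)(C)OC(=O)N1CCN(C(=S)SCc2cn(C[C@H](O)[C@H]3OC(=O)C(OCc4ccccc4)=C3OCc3ccccc3)nn2)CC1`: for compound 2 this assay reports only a limit, > 100000 nM.

Among the measured compounds shown here, compound 1 stands alone with a number in this assay, since the only other value shown is a limit. For the measured compounds named here, that limit, (the limit of > 100000 nM in this assay, at which 1 of the 2 values shown sits), belongs to compound 2, whose dithiocarbamate-linked piperazine side chain differs from compound 1 in more than one place, so it offers no single measured step to lean on.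

Compound 3 `O=C1O[C@H]([C@@H](O)Cn2cc(-c3cc(F)cc(F)c3)nn2)C(OCc2ccccc2)=C1OCc1ccccc1` is not yet measured. It differs from compound 1 by 3,5-difluorophenyl in place of 4-pentylphenyl on an aromatic carbon. With no measured step of this kind among the compounds shown, the size and direction of the change cannot be read from data here. The expectation is a step from compound 1 to compound 3 of a 2.2-fold higher number from compound 1 to compound 3 (0.34 log units; beyond the scatter), toward a weaker inhibitor but possibly within the scatter. Compound 3 is therefore estimated at 30000 nM, with a likely range from 8000 nM to 100000 nM.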

Compound 3, half-maximal inhibitory concentration: 48200 nM
Beside the measured number, compound 3's estimate is 1.6-fold (0.21 log units) below it; low and high end bracket the measured number.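

Among the compounds shown here, replacing 4-pentylphenyl with 3,5-difluorophenyl on the aromatic carbon of the five-membered aromatic ring with 3 nitrogen gives in this assay a 3.5-fold higher number from compound 1 to compound 3 (0.54 log units; beyond the scatter) and so shows for the first time that this position responds to a change of group, here with a modest move toward a weaker inhibitor. Both groups keep one six-membered aromatic ring of carbon only, so the exchange lies in what that ring carries, but this single step combines the loss of the pentyl chain with the arrival of two fluorine atoms and cannot separate the two. Compound 2 still supplies no number for comparison, only a limit: the limit of > 100000 nM in this assay, at which 1 of the 3 values shown sits.

The compounds shown leave open whether removing the pentyl chain or adding the fluorine atoms matters more, and a plain phenyl ring would help to separate those two parts of the change. They also leave open whether a longer chain in place of the pentyl chain, or an amine on the aromatic ring, would move the number in either direction.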